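Replacing a phenyl with pyridin-2-yl on compound 1

A few compounds are considered here, and "the series" means these few. Any claim that something is new, unique, unknown or untested is made for them only; others in the source may bear on it.

Compound 1 `O=C(c1ccccc1)N1CCC(C(=O)N2N=CCC2c2ccccc2)CC1` was examined in a physicochemical assay for lipophilicity, read by HPLC, measured as chromatographic lipophilicity, at pH 7.4 (on this read-out higher numbers stand for higher lipophilicity and lower numbers for lower lipophilicity), where compound 1 gives 4.4. Compound 2 `CC(C)(C)C(=O)N1CCC1c1ccccc1` gives 5, a higher number than that of compound 1 by a margin beyond the usual scatter. Compound 3 `CC(C)(C)C(=O)N1N=CCC1c1ccc(S(C)(=O)=O)cc1` gives 4.1, a number that lies within the scatter of the value of compound 1, so the two cannot be told apart. Compound 4 `O=C(c1ccccn1)N1CCC(C(=O)N2N=CCC2c2ccccc2)CC1` has not yet been measured; it differs from compound 1 in one place, (pyridin-2-yl in place of phenyl on a carbonyl carbon). Among the compounds with values here, no pair among the measured compounds shows this change, so its size here is not known. Compound 4 is expected to give a lower number, a step from compound 1 to compound 4 of about a number 0.90 log units lower from compound 1 to compound 4 (beyond the scatter). The estimate for compound 4 is 3.5, within a range from 2.9 to 4.1.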

Compound 4, distribution coefficient: 3.1
Beside the measured number, compound 4's estimate is 0.40 log units above it, within the range that was stated.
By their numbers in this assay, from the lowest: compound 4; then compounds 3 and 1 (each within the scatter of the next); then compound 2.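

On the carbonyl carbon of the core of compound 1, pyridin-2-yl in place of phenyl keeps the heavy-atom count and adds one hydrogen-bond acceptor. In this assay, this single change gives a number 1.30 log units lower from compound 1 to compound 4 (beyond the scatter), the first step read at this position, and it shows that the read-out responds strongly to this exchange of rings. No measurement at hand explains the size of this step. As far as these compounds go, whether the same change gives a similar step on another core remains open. So does the effect of a different ring at this place, such as thiophene or pyrimidine.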